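Fluorophenoxy variants: compound 2 to compound 3

The source may report more compounds than this note shows. Statements on the series, on what has been measured and on what is new or still open speak of the compounds shown alone.

Values in a functional assay on Jurkat cells (Homo sapiens); on this read-out higher numbers stand for weaker inhibition and lower numbers for stronger inhibition:
Compound 1 `CC(C)[C@H](NC(=O)COc1cccc2ccccc12)C(=O)N[C@@H](CC(=O)O)C(=O)COc1ccc(F)cc1F`: 33200 nM
Compound 2 `CC(C)[C@H](NC(=O)COc1cccc2ccccc12)C(=O)N[C@@H](CC(=O)O)C(=O)COc1ccc(F)c(F)c1`: > 100000 nM
Compound 3 `CC(C)[C@H](NC(=O)COc1cccc2ccccc12)C(=O)N[C@@H](CC(=O)O)C(=O)COc1cc(F)cc(F)c1F`: not yet measured

Compound 2 gives only a limit and no number (the limit of > 100000 nM in this assay, at which 1 of the 2 values shown sits). Compound 3 keeps the shared core and carries 2,3,5-trifluorophenyl in place of 3,4-difluorophenyl on an oxygen on a saturated carbon. Among the compounds with values here, one measured step bears on this change, and it also concerns the group at that place: an at least 3.0-fold higher number from compound 1 to compound 2 (0.47 log units; beyond the scatter) is the move from 2,4-difluorophenyl to 3,4-difluorophenyl. Compound 3 also lacks 3,4-difluorophenyl, so a lower number than for compound 2 is expected in this assay, since compound 1 gives 33200 nM without that group. This expectation rests on a single step and is loose, and a second reading at the limit remains possible. The expected change is an at least 5.0-fold lower number from compound 2 to compound 3 (0.69 log units; beyond the scatter) (an estimate, not a measurement). For compound 3 the estimated value is 20000 nM (expected range 3000 nM to 100000 nM).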

Compound 3, half-maximal inhibitory concentration: 30000 nM
For compound 3 the middle estimate is 1.5-fold (0.18 log units) below the measured one; low and high end bracket the measured number.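

In this assay, 2,3,5-trifluorophenyl in place of 3,4-difluorophenyl on an oxygen on a saturated carbon returns the series to a measurable number: an at least 3.3-fold lower number from compound 2 to compound 3 (0.52 log units; beyond the scatter). The poor result of compound 2 therefore does not extend to every fluorinated phenyl group at this place, and it now stands as specific to 3,4-difluorophenyl among the three groups shown. The comparison with the other measurable compound gives a 1.1-fold lower number from compound 1 to compound 3 (0.04 log units; within the scatter), so 2,4-difluorophenyl and 2,3,5-trifluorophenyl cannot be told apart in this assay, and the change from two to three fluorines brings no visible gain between these two groups.

Compound 2 gives a limit of the assay and not a number, so the true size of its step stays unfixed: the limit of > 100000 nM in this assay, at which 1 of the 3 values shown sits. From the compounds shown here alone, what an unsubstituted phenyl, a chlorophenyl or a methoxyphenyl group would give at this place stays open, as does whether any group on this oxygen can reach a clearly lower number than compound 1 and compound 3 share.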